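The source may report more compounds than this note shows. Statements on the series, on what has been measured and on what is new or still open speak of the compounds shown alone.

Working notes on the series. Compound 3 `Cc1cc(-c2ccccc2NCC2=NCCN2)on1` gives 38.9 nM in a functional assay for activation of Alpha-1A adrenergic receptor (Homo sapiens), read by calcium flux (a higher number here means that more compound is needed for the effect, a lower number that less compound is needed), the highest of the three numbers measured. Compound 1 `c1ccc(-c2cnco2)c(NCC2=NCCN2)c1` gives 17.4 nM and compound 2 `c1csc(-c2ccccc2NCC2=NCCN2)c1` gives 2.24 nM, so compound 3 sits above both by steps beyond the scatter. Compound 4 `c1ccc(-c2ccccc2NCC2=NCCN2)nc1` differs from compound 3 in one place: pyridin-2-yl in place of 3-methyl-1,2-oxazol-5-yl on an aromatic carbon. The measured steps at this position were a 7.8-fold lower number from compound 1 to compound 2 (0.89 log units; beyond the scatter), a 2.2-fold higher number from compound 1 to compound 3 (0.35 log units; beyond the scatter) and a 17-fold higher number from compound 2 to compound 3 (1.24 log units; beyond the scatter); each swap of the ring here moved the number beyond the scatter, with the five-membered rings holding two hetero atoms giving the higher numbers. A lower number is therefore expected for compound 4, as a 4.9-fold lower number from compound 3 to compound 4 (0.69 log units; beyond the scatter). Compound 4 is estimated at 8 nM, within a range of 1.5 nM to 40 nM.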

Compound 4, half-maximal effective concentration: 6.76 nM
For compound 4 the middle estimate is 1.2-fold (0.07 log units) above the measured one; low and high end bracket the measured number.
By their numbers in this assay, from the lowest: compound 2; then compound 4; then compound 1; then compound 3.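

Pyridin-2-yl, the only six-membered ring here, gives a 5.8-fold lower number from compound 3 to compound 4 (0.76 log units; beyond the scatter) and also a 2.6-fold lower number from compound 1 to compound 4 (0.41 log units; beyond the scatter) but still leaves a 3.0-fold higher number from compound 2 to compound 4 (0.48 log units; beyond the scatter) in this series. The two rings with 1 hetero atom, in compound 2 and compound 4, therefore both give lower numbers than the five-membered rings with 2 hetero atoms, in compound 1 and compound 3, with no listed compound against this, so ring size alone does not set the order here. No data on hand account for this ranking. As far as these compounds go, whether an unsubstituted phenyl or a saturated ring such as piperidine would continue this order remains open, as does the effect of a methyl group on the pyridin-2-yl ring.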